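The compounds below may be only part of what the source reports. "The series", "measured", "known", "first", "only" and "open" are said of these compounds alone.

In an ADME assay on WI-38 cells (Homo sapiens) for cytotoxicity, read by MTT assay, with a stated time of 72 h (a lower number here means a stronger inhibitor, a higher number a weaker inhibitor), compound 2 `CN(C)CCn1cnnc1-c1cc(Oc2ccc(NC(=O)N/N=C/c3ccc(O)c(Br)c3)cc2F)ccn1` gives 5560 nM, the highest of the three numbers here, though compound 3 `CN(C)CCn1cnnc1-c1cc(Oc2ccc(NC(=O)N/N=C/c3ccc(F)cc3F)cc2F)ccn1` gives 5030 nM and compound 1 `CN(C)CCn1cnnc1-c1cc(Oc2ccc(NC(=O)N/N=C/c3c(Cl)cccc3Cl)cc2F)ccn1` gives 3320 nM, and all three lie within the scatter of one another. The step from compound 2 to compound 4 `CN(C)CCn1cnnc1-c1cc(Oc2ccc(NC(=O)N/N=C/c3ccc(F)cc3Cl)cc2F)ccn1` is 2-chloro-4-fluorophenyl in place of 3-bromo-4-hydroxyphenyl on a carbon with a double bond to nitrogen. The relevant measured steps are a 1.7-fold higher number from compound 1 to compound 2 (0.22 log units; within the scatter), a 1.5-fold higher number from compound 1 to compound 3 (0.18 log units; within the scatter) and a 1.1-fold lower number from compound 2 to compound 3 (0.04 log units; within the scatter), none of them beyond the scatter. Since exchanging one substituted phenyl for another on this carbon has so far moved nothing beyond the scatter, compound 4 is expected to show no step beyond the scatter either, a 1.2-fold lower number from compound 2 to compound 4 (0.09 log units; within the scatter). Compound 4 is therefore estimated at 4500 nM, with a range from 2500 nM to 8500 nM.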

Compound 4, half-maximal inhibitory concentration: 2090 nM
The estimate for compound 4 lay 2.2-fold (0.33 log units) above the measured number, and the stated range ends above it.
By their numbers in this assay, from the lowest: compounds 4, 1, 3 and 2 (each within the scatter of the next, the first and the last beyond it).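

In this assay, this position now gives steps beyond the scatter, a 2.7-fold lower number from compound 2 to compound 4 (0.42 log units; beyond the scatter) and, for chloro in place of fluoro on an aromatic carbon alone, a 2.4-fold lower number from compound 3 to compound 4 (0.38 log units; beyond the scatter), while a 1.6-fold lower number from compound 1 to compound 4 (0.20 log units; within the scatter) stays within it. A single halogen exchange on the phenyl is thus enough for a modest step, although compound 1, also a chloro compound, does not separate from compound 4. Nothing measured here accounts for this. Still open, on these data alone, is whether methyl or methoxy in place of the chloro of the 2-chloro-4-fluorophenyl would keep the number of compound 4.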